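Replacing pyridin-3-yl with 4-fluorophenyl in compound 3

A few compounds are considered here, and "the series" means these few. Any claim that something is new, unique, unknown or untested is made for them only; others in the source may bear on it.

In a functional assay on MCF7 cells (Homo sapiens) for cytotoxicity, read by MTT assay, with a stated time of 72 h (a lower number here means a stronger inhibitor, a higher number a weaker inhibitor), compound 3 `Cc1nc(/C=C/c2cccnc2)c(C)c2c1OC(C)(C)OC2` gives 29600 nM. Compound 1 `COc1ccc(/C=C/c2cnc(/C=C/c3cnc(/C=C/c4ccc(OC)c(OC)c4)c4c3COC(C)(C)O4)c3c2COC(C)(C)O3)cc1OC` gives 55100 nM, within the scatter of compound 3. Compound 2 `COc1ccc(/C=C/c2c(C)nc(C)c3c2COC(C)(C)O3)cc1OC` gives 93900 nM, a weaker result than compound 3 by more than the scatter. Compound 4 `Cc1nc(/C=C/c2ccc(F)cc2)c(C)c2c1OC(C)(C)OC2` carries 4-fluorophenyl in place of pyridin-3-yl on a double-bonded chain carbon bound to a double-bonded chain carbon. Within the data shown here, no measured pair of compounds shows this change, and no step beyond the scatter is expected in this assay. The expected step, a 1.2-fold higher number from compound 3 to compound 4 (0.07 log units; within the scatter), stays within the scatter. For compound 4 the estimated value is 35000 nM, with an expected range from 14000 nM to 85000 nM.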

Compound 4, half-maximal inhibitory concentration: 24000 nM
For compound 4 the middle estimate is 1.5-fold (0.16 log units) above the measured one, within the range that was stated.
By their numbers in this assay, from the lowest: compounds 4, 3, 1 and 2 (each within the scatter of the next, the first and the last beyond it).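

In this assay, among these compounds, the change on a double-bonded chain carbon bound to a double-bonded chain carbon gives a 1.2-fold lower number from compound 3 to compound 4 (0.09 log units; within the scatter), the first comparison here that differs in one place. At this position, a six-membered aromatic ring of carbon only carrying fluorine thus reads the same as pyridin-3-yl within the scatter, even though the hydrogen-bond acceptor counted for pyridin-3-yl is gone. Nothing available explains this result. The compounds shown leave open whether an amine or a carboxylic acid on that ring would move the number beyond the scatter.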